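Removing the azido group from the aryl end

The source may report more compounds than this note shows. Statements on the series, on what has been measured and on what is new or still open speak of the compounds shown alone.

For the measured compounds named here, compound 1 `[N-]=[N+]=Nc1ccc(CCCCC(O)/C=C/C2CCCC(O)(CC(=O)O)C2)cc1` gives 2000 nM in an assay on cell membranes for inhibition of leukotriene B4 receptor 1 (Homo sapiens), read by radioligand binding (on this read-out higher numbers stand for weaker inhibition and lower numbers for stronger inhibition), the only value shown for it. Compound 2 `CN(C)C(=O)CC1(O)CCCC(/C=C/C(O)CCCCc2ccc(N=[N+]=[N-])cc2)C1` gives 2000 nM; 700 nM (2 entries) in this assay; its repeated entries the several entries of compound 2 in this assay, 2000 nM; 700 nM (2 entries) show the spread of such measurements rather than any structural step. Compound 3 `O=C(O)CC1(O)CCCC(/C=C/C(O)CCCCc2ccccc2)C1` is the open question: hydrogen in place of azido on an aromatic carbon. Going by the values given here, no measured pair covers this change, and compound 2 differs at the other end of the chain. The expected step is therefore small, a 1.3-fold lower number from compound 1 to compound 3 (0.12 log units; within the scatter), in no clear direction. For compound 3 the expected value in this assay is 1500 nM, with a range from 400 nM to 6000 nM.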

Compound 3, half-maximal inhibitory concentration: 300 nM
The estimate for compound 3 lay 5.0-fold (0.70 log units) above the measured number; the whole stated range lies above it.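

In this assay, for the compounds shown here, the change from 4-azidophenyl to phenyl gives a 6.7-fold lower number from compound 1 to compound 3 (0.82 log units; beyond the scatter), the first reading of this aromatic carbon, since the earlier compounds both carry azido there. Hydrogen is thus better tolerated here than azido, with no need for a group at this position to keep inhibition. The step remains modest, and entries for a single compound can differ noticeably: the several entries of compound 2 in this assay, 2000 nM; 700 nM (2 entries)

Going by these compounds, whether an amine or a methoxy group on this carbon would read like azido or like hydrogen stays open. Also open, on these data alone, is whether the same change holds with the amide end of compound 2.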